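The source may report more compounds than this note shows. Statements on the series, on what has been measured and on what is new or still open speak of the compounds shown alone.

Working notes on the series. Compound 1 `CN1CCN(c2cccc3[nH]c(C(=O)c4ccccc4)nc23)CC1` carries the 4-methylpiperazin-1-yl group; in an assay on HEK293 cells for displacement of a labelled ligand from 5-hydroxytryptamine receptor 6 (Homo sapiens), read by scintillation counting (a lower number here means a stronger inhibitor, a higher number a weaker inhibitor), compound 1 returns only a limit, > 1000 nM. Compound 2 `CN1CCN(c2ccc3[nH]c(C(=O)c4ccc5ccccc5c4)nc3c2)CC1` likewise returns only a limit in this assay, > 1000 nM. For the measured compounds named here, compound 3 `c1ccc(Cc2nc3c(N4CCNCC4)cccc3[nH]2)cc1`, which carries the unsubstituted piperazin-1-yl group, gives the only real number in this assay, 58 nM; the two other results sit at the limit of > 1000 nM in this assay, at which 2 of the 3 values shown sit. Compound 4 `CN1CCN(c2cccc3[nH]c(Cc4ccccc4)nc23)CC1` is the next step from compound 3: methyl in place of hydrogen on an amine nitrogen in a ring. Going by the values given here, no measured pair isolates this change, and compounds 1 and 2 differ from compound 3 in more than one place, so they give no direct guide. The step of a 2.6-fold higher number from compound 3 to compound 4 (0.41 log units; beyond the scatter) is expected to be a modest loss, somewhat beyond the scatter. Compound 4 is expected near 150 nM, within 40 nM to 700 nM.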

Compound 4, inhibition constant: 66.8 nM
For compound 4 the middle estimate is 2.2-fold (0.35 log units) above the measured one, and the stated range covers the measured number.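

The step from piperazin-1-yl to 4-methylpiperazin-1-yl can now be read directly in this assay, and the two compounds stand level: a 1.2-fold higher number from compound 3 to compound 4 (0.06 log units; within the scatter). With 4-methylpiperazin-1-yl held constant, benzyl in place of benzoyl on an aromatic carbon gives the large step, an at least 14-fold lower number from compound 1 to compound 4 (1.17 log units; beyond the scatter). Compound 1 stands only as a limit: the limit of > 1000 nM in this assay, at which 2 of the 4 values shown sit.

From the compounds shown here alone, whether methyl is equally tolerated with benzoyl in place of benzyl remains open. Also open, going by these compounds, is what ethyl or a longer chain on that ring nitrogen would give.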